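Bromo on the thiophene of compound 3

A few compounds are considered here, and "the series" means these few. Any claim that something is new, unique, unknown or untested is made for them only; others in the source may bear on it.

For the measured compounds named here, compound 3 `C[C@H]1[C@H](NCc2cccs2)C[C@H]2C[C@@H]1C2(C)C` stands at the lower of the two numbers so far in an ADME assay on MDCK cells (Canis lupus familiaris) for cytotoxicity, read by microscopy, with a stated time of 48 h (on this read-out higher numbers stand for lower toxicity in this test and lower numbers for higher toxicity in this test), giving 25000 nM. Compound 2 `C=Cc1ccsc1CN[C@@H]1C[C@H]2C[C@@H]([C@H]1C)C2(C)C` gives 50000 nM in this assay, and the step of a 2.0-fold lower number from compound 2 to compound 3 (0.30 log units; within the scatter) is the exchange of hydrogen for vinyl on an aromatic carbon. Compound 1 `C[C@H]1[C@H](NCc2cncnc2)C[C@H]2C[C@@H]1C2(C)C` returns only a limit, > 100000 nM. The step of an at least 4.0-fold lower number from compound 1 to compound 3 (0.60 log units; beyond the scatter) swaps thiophen-2-yl for pyrimidin-5-yl on the saturated chain carbon bound to the amine nitrogen; its size is bounded by the limit of > 100000 nM in this assay, at which 1 of the 3 values shown sits.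

Compound 4 `C[C@H]1[C@H](NCc2sccc2Br)C[C@H]2C[C@@H]1C2(C)C` differs from compound 3 by bromo in place of hydrogen on an aromatic carbon. The step that bears on it most, a 2.0-fold lower number from compound 2 to compound 3 (0.30 log units; within the scatter), is likewise a change of a small group on an aromatic carbon and stayed within the scatter; the larger step of an at least 4.0-fold lower number from compound 1 to compound 3 (0.60 log units; beyond the scatter) replaced the whole ring and is less comparable. A step within the scatter is therefore expected for a 1.3-fold lower number from compound 3 to compound 4 (0.10 log units; within the scatter), perhaps leaning toward a slightly lower number. Compound 4 is estimated at 20000 nM, within 8000 nM to 50000 nM.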

Compound 4, minimum cytotoxic concentration: 50000 nM
For compound 4 the middle estimate is 2.5-fold (0.40 log units) below the measured one; low and high end bracket the measured number.
By their numbers in this assay, from the lowest: compounds 3, 2 and 4 (each within the scatter of the next). At a limit, above all of these: compound 1.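

In this assay, the aromatic carbon next to the ring atom that bears a large group now holds a second substituent, and neither a 2.0-fold higher number from compound 3 to compound 4 (0.30 log units; within the scatter) nor no change at the digits printed from compound 2 to compound 4 (within the scatter) leaves the scatter, so hydrogen, vinyl and bromo at this place cannot be told apart. Replacing the pyrimidin-5-yl with 3-bromothiophen-2-yl gives an at least 2.0-fold lower number from compound 1 to compound 4 (0.30 log units; that floor lies within the scatter), a floor that, unlike the step to the unsubstituted thiophene, does not clear the scatter. Compound 1 is held at a limit, not a number, so this step has no upper bound: the limit of > 100000 nM in this assay, at which 1 of the 4 values shown sits.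

The compounds shown leave open whether a different group at this place, such as a methoxy, a nitrile or a carboxylic acid, would stay within the scatter. They also leave open whether bromo on another aromatic carbon of the thiophene would read the same.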